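Pyridine to Pyrimidine on the Amine of Compound 3

This account rests on a few compounds, and the source may have more. Where it says the series, first, only, none or still open, it means among the compounds named here.

Among the compounds with values here, compound 3 `C[C@@H](Cn1ccc(-c2ccc(C#N)c(Cl)c2)n1)Nc1cccnc1` gives 430 nM in a functional assay on LNCaP cells (Homo sapiens) for antiproliferative activity, read by CCK-8 assay, with a stated time of 6 days (on this read-out higher numbers stand for weaker inhibition and lower numbers for stronger inhibition), the lowest of the three numbers measured so far. Compound 1 `C[C@@H](Cn1ccc(-c2ccc(C#N)c(Cl)c2)n1)NC(=O)c1ccccc1F` gives 1810 nM and compound 2 `C[C@@H](Cn1ccc(-c2ccc(C#N)c(Cl)c2)n1)NC(=O)C1CC(=O)C1` gives 3040 nM, with a 4.2-fold lower number from compound 1 to compound 3 (0.62 log units; beyond the scatter) and a 7.1-fold lower number from compound 2 to compound 3 (0.85 log units; beyond the scatter). Compound 4 `C[C@@H](Cn1ccc(-c2ccc(C#N)c(Cl)c2)n1)Nc1cncnc1` differs from compound 3 by pyrimidin-5-yl in place of pyridin-3-yl on an amine nitrogen. Within the data shown here, none of the measured steps bears directly on this change: both measured steps replace an amide with an amine, whereas compound 3 to compound 4 keeps the amine and exchanges one aromatic ring for another. On that basis only a step within the scatter is expected, a 1.4-fold higher number from compound 3 to compound 4 (0.14 log units; within the scatter). For compound 4 a value of 600 nM is estimated, in the range 250 nM to 1500 nM.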

Compound 4, half-maximal inhibitory concentration: 2070 nM
Estimate against measurement, compound 4: 3.5-fold (0.54 log units) below; measured number outside the range, above it.
By their numbers in this assay, from the lowest: compound 3; then compounds 1, 4 and 2 (each within the scatter of the next).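

In this assay, the ring on the amine nitrogen matters even when the amine stays: pyrimidin-5-yl, with its second ring nitrogen, gives a clear loss against pyridin-3-yl (a 4.8-fold higher number from compound 3 to compound 4 (0.68 log units; beyond the scatter)). The amine link alone therefore does not secure the gain over the amides, as compound 4 cannot be told apart from either (a 1.5-fold lower number from compound 2 to compound 4 (0.17 log units; within the scatter); a 1.1-fold higher number from compound 1 to compound 4 (0.06 log units; within the scatter)). No evidence here explains the loss. Still open, as far as these compounds go, is whether phenyl or pyridin-4-yl on this amine nitrogen would match or improve on compound 3.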